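Trifluoromethyl to carboxy on the terminal aromatic ring

The compounds below may be only part of what the source reports. "The series", "measured", "known", "first", "only" and "open" are said of these compounds alone.

Measured compounds:
Compound 1 `Cc1n[nH]c(C(=O)O)c1Cc1cccc(-c2ccc(OC(F)(F)F)cc2)c1` in an assay on isolated protein for inhibition of 2-Hydroxyacid oxidase 2 (Homo sapiens), tested at 10 uM (a higher number here means a stronger effect of the compound at the concentration tested, a lower number a weaker effect), gives 34%.
Compound 2 `Cc1n[nH]c(C(=O)O)c1Cc1cccc(-c2ccc(C(N)=O)cc2)c1` in this assay gives 60%.
Compound 3 `Cc1n[nH]c(C(=O)O)c1Cc1cccc(-c2ccc(C(F)(F)F)cc2)c1` in this assay gives 30%.

Compound 3 has the lowest of the three numbers. Its nearest neighbour is compound 1, and the two stand within the scatter of each other, as a number 4 percentage points lower from compound 1 to compound 3 (within the scatter) shows. The gap to compound 2 is beyond the scatter: a number 30 percentage points lower from compound 2 to compound 3 (beyond the scatter).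

Compound 4 `Cc1n[nH]c(C(=O)O)c1Cc1cccc(-c2ccc(C(=O)O)cc2)c1` differs from compound 3 in one place: carboxy in place of trifluoromethyl on an aromatic carbon. The step that bears most on this is the reverse of the change from carbamoyl to trifluoromethyl, where a number 30 percentage points lower from compound 2 to compound 3 (beyond the scatter); the same group also separates compound 1 from compound 2, with a number 26 percentage points higher from compound 1 to compound 2 (beyond the scatter). Carboxy brings a hydrogen-bond donor and acceptor where trifluoromethyl has none, which is what carbamoyl also brought. A rise of roughly the size seen for carbamoyl is therefore expected, as a number 25 percentage points higher from compound 3 to compound 4 (beyond the scatter). Compound 4 is estimated at 55%, within the range 35% to 75%.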

Compound 4, a percentage reported as inhibition, at one concentration (the size of the read-out at that concentration, not a potency): 15%
For compound 4 the middle estimate is 40 percentage points above the measured one; the whole stated range lies above it.
By their numbers in this assay, from the lowest: compound 4; then compounds 3 and 1 (each within the scatter of the next); then compound 2.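

Carboxy at this position, para to a large group, sits at the bottom of the series in this assay and gives a number 15 percentage points lower from compound 3 to compound 4 (beyond the scatter) as well as a number 19 percentage points lower from compound 1 to compound 4 (beyond the scatter) against the trifluoromethoxy compound. A group with a hydrogen-bond donor and acceptor on this aromatic carbon therefore does not by itself raise the number, and the rise seen with carbamoyl does not extend to carboxy. The change at the carbonyl carbon alone, hydroxy in place of amino, gives a number 45 percentage points lower from compound 2 to compound 4 (beyond the scatter) and is the largest step in the series, but nothing available explains it.

On these data alone, it remains open whether the gain with carbamoyl depends on the amino group itself or on its hydrogens. A methyl ester, an N-methyl amide or a sulfonamide on this carbon would bear on that.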